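The compounds below may be only part of what the source reports. "The series", "measured", "known", "first", "only" and "open" are said of these compounds alone.

Measured compounds:
compound 1, `CC(C)c1ccc(OCCCCCn2ccc(=O)[nH]c2=O)cc1`: > 100000 nM
compound 2, `O=c1ccn(CCCCOc2ccc(Br)cc2)c(=O)[nH]1`: "not determined" (no result reported)

Two compounds have been run in an ADME assay on HEL cells (Homo sapiens) for cytotoxicity; on this read-out lower numbers stand for higher toxicity in this test and higher numbers for lower toxicity in this test. Compound 1 gives > 100000 nM, and this value is a limit of the assay rather than a number. Compound 2 gives "not determined" (no result reported), which means no result exists for it. On the numbers shown, compound 1 stands at the limit of > 100000 nM in this assay, at which 1 of the 2 values shown sits, and with no second number there is no step between measured compounds to compare against.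

Compound 3, `Nc1ccc(OCCCCCn2ccc(=O)[nH]c2=O)cc1`, is not yet measured. It differs from compound 1 in one place: amino in place of isopropyl on an aromatic carbon. Among the compounds with values here, no measured pair shows what such a change does to the read-out in this assay, so the expectation rests on compound 1 alone. Because compound 1 sits at the limit of > 100000 nM in this assay, at which 1 of the 2 values shown sits, compound 3 is expected to stay in the same region, without a step beyond the usual scatter. The step in this assay is expected to be a number no higher from compound 1 to compound 3 (the limit leaves the size open). Compound 3 is estimated at 100000 nM, ranging from 30000 nM to 300000 nM, and the assay would most likely again report only a limit.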

Compound 3, half-maximal cytotoxic concentration: > 100000 nM
Compound 3: a limit, no number (the forecaster's own chance of this, stated with the estimate: 75%); the middle value sits exactly at the limit.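

In this assay compound 1 and compound 3 each give only a limit of the assay, not a number, and the step between them cannot be read: the limit of > 100000 nM in this assay, at which 2 of the 3 values shown sit. The compounds shown leave open what the true values are, and whether amino in place of isopropyl changes this read-out at all.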